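A few compounds are considered here, and "the series" means these few. Any claim that something is new, unique, unknown or untested is made for them only; others in the source may bear on it.

Compound 1 `Cc1oc(C(=O)NS(=O)(=O)c2ccccc2)cc1COc1ccc(-c2ccccc2)cc1` gives the lowest of the two numbers shown in an assay on cells for displacement of a labelled ligand from prostaglandin E2 receptor EP4 subtype (Homo sapiens), read by scintillation counting (on this read-out higher numbers stand for weaker inhibition and lower numbers for stronger inhibition), where compound 1 gives 25 nM. Compound 2 `Cc1oc(C(=O)O)cc1COc1ccc(-c2ccccc2)cc1` gives 420 nM, so the step of a 17-fold higher number from compound 1 to compound 2 (1.23 log units; beyond the scatter) follows hydroxy in place of (phenylsulfonyl)amino on a carbonyl carbon. Compound 3 `Cc1oc(C(=O)O)cc1COc1ccc(-c2ccoc2)cc1` reaches only a limit of the assay, > 10000 nM. The step of an at least 23-fold higher number from compound 2 to compound 3 (1.37 log units; beyond the scatter) followed furan-3-yl in place of phenyl on an aromatic carbon. Compound 4 `COc1ccc(-c2ccc(OCc3cc(C(=O)NS(=O)(=O)c4ccccc4)oc3C)cc2)nc1` differs from compound 1 by 5-methoxypyridin-2-yl in place of phenyl on an aromatic carbon. The step from compound 2 to compound 3 bears on this change, as it too swapped that phenyl for a ring holding a hetero atom; the incoming ring here stays six-membered, so a smaller loss is expected. Compound 4 is estimated at 60 nM, between 15 nM and 250 nM, an expected step of a 2.4-fold higher number from compound 1 to compound 4 (0.38 log units; beyond the scatter).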

Compound 4, inhibition constant: 22 nM
Compound 4: the middle estimate sits 2.7-fold (0.44 log units) above what was measured, and the stated range covers the measured number.
By their numbers in this assay, from the lowest: compounds 4 and 1 (each within the scatter of the next); then compound 2. At a limit, above all of these: compound 3.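

In this assay, 5-methoxypyridin-2-yl in place of phenyl gives a 1.1-fold lower number from compound 1 to compound 4 (0.06 log units; within the scatter), so this position accepts a larger ring holding a hetero atom, at least on the core of compound 1. Among the compounds shown here, the only earlier change here was furan-3-yl, and compound 3, which carries it on the carboxylic acid, stands at a limit of the assay: the limit of > 10000 nM in this assay, at which 1 of the 4 values shown sits A hetero atom in this ring therefore does not always go with a large loss, and compound 3 remains the case against. From the compounds shown here alone, the ring nitrogen and the methoxy arrive together, so how each counts alone stays open: a plain pyridin-2-yl or a 4-methoxyphenyl group would separate them.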